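Methoxy Addition on Two Cores in a Cytotoxicity Assay

The compounds below may be only part of what the source reports. "The series", "measured", "known", "first", "only" and "open" are said of these compounds alone.

Measured compounds:
Compound 1, `CC(=O)Nc1ccc(O)c(C(=O)/C=C/c2ccccc2)c1`: 85500 nM
Compound 2, `COc1ccc(/C=C/C(=O)c2cc(NC(C)=O)ccc2O)cc1`: 59200 nM
Compound 3, `Nc1ccc2oc(-c3ccccc3)c(O)c(=O)c2c1`: 27000 nM

All three were tested in an ADME assay on THP-1 cells (Homo sapiens) for cytotoxicity, read by flow cytometry and propidium iodide staining, with a stated time of 72 h; on this read-out lower numbers stand for stronger inhibition and higher numbers for weaker inhibition. Compound 1 and compound 2 share one core, and compound 2 carries methoxy in place of hydrogen on an aromatic carbon. The step of a 1.4-fold lower number from compound 1 to compound 2 (0.16 log units; within the scatter). Compound 3 stands on a different core; the difference between the two cores is not broken down here. Compound 3 gives the lowest number of the three, with compound 2 nearest to it and compound 1 furthest, both gaps beyond the scatter.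

Compound 4, `COc1cccc(-c2oc3ccc(N)cc3c(=O)c2O)c1`, has not yet been measured. It differs from compound 3 by methoxy in place of hydrogen on an aromatic carbon. The two places are not identical: in compound 2 the methoxy sits para to a large group, in compound 4 meta to a large group, so this is the same kind of change rather than the same change. Because a 1.4-fold lower number from compound 1 to compound 2 (0.16 log units; within the scatter) stayed within the scatter, a comparable step is expected here, a 1.2-fold lower number from compound 3 to compound 4 (0.09 log units; within the scatter). Compound 4 is therefore expected to give about 22000 nM in this assay, with a plausible range from 10000 nM to 50000 nM.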

Compound 4, half-maximal inhibitory concentration: 2000 nM
For compound 4 the middle estimate is 11-fold (1.04 log units) above the measured one; measured number outside the range, below it.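

In this assay, methoxy in place of hydrogen on an aromatic carbon gives a 14-fold lower number from compound 3 to compound 4 (1.13 log units; beyond the scatter), and the size of this step does not carry over between the two cores: the same change on two cores in this assay, a 1.4-fold lower number (0.16 log units; within the scatter) from compound 1 to compound 2 and a 14-fold lower number (1.13 log units; beyond the scatter) from compound 3 to compound 4, 9.3-fold (0.97 log units) apart, beyond the scatter of two such steps In this series, then, the step seen on the core of compound 1 did not predict the size of the step on the core of compound 3. This does not show that the core alone sets the size of the step, since the methoxy also sits in a different place in the two pairs, and each core offers only one pair, so the shown data cannot separate the two differences or give a reason for the gap.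

The compounds shown leave open whether methoxy on the core of compound 3, placed as it is in compound 2, would give a step of similar size. They also leave open whether an ethoxy group or a chlorine atom, meta to a large group on that core, would behave as methoxy does in compound 4.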